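The source may report more compounds than this note shows. Statements on the series, on what has been measured and on what is new or still open speak of the compounds shown alone.

In an ADME assay on L6 cells (Rattus norvegicus) for cytotoxicity, read by resazurin assay, with a stated time of 72 h (a lower number here means a stronger inhibitor, a higher number a weaker inhibitor), compound 1 (`CN(C)C12CC(OC(=O)CN3CCCC3)C(C(c3ccccc3)C1)C(c1ccccc1)C2`) gives 32700 nM, compound 2 (`CN1CCN(CCC(=O)N2CCC3(N(C)C)CC(c4ccccc4)C2C(c2ccccc2)C3)CC1`) gives 128000 nM and compound 3 (`CN1CCN(CC(=O)N2CCC3(N(C)C)CC(c4ccccc4)C2C(c2ccccc2)C3)CC1`) gives 195000 nM. Compound 3 thus stands level with compound 2 within the scatter, while the number for compound 1 lies lower than both. Compound 4 (`CN1CCN(CC(=O)N2CCC3(N4CCCCC4)CC(c4ccccc4)C2C(c2ccccc2)C3)CC1`) differs from compound 3 in one group: piperidin-1-yl in place of dimethylamino on a saturated ring carbon. In words, it has piperidin-1-yl in place of dimethylamino on a saturated ring carbon. All three measured compounds carry dimethylamino, so the data hold no measured change at that group. Going by the values given here, the one measured step, a 1.5-fold higher number from compound 2 to compound 3 (0.18 log units; within the scatter), concerns the (4-methylpiperazin-1-yl)methyl group instead and gives no direct guide. Among the compounds with values here, compound 1, at 32700 nM, shows only that lower numbers occur in this small set, so a small move toward a lower number in this assay is expected, with no change also possible. The expected step is a 2.0-fold lower number from compound 3 to compound 4 (0.29 log units; within the scatter). For compound 4 the estimated value is 100000 nM, with an expected range from 35000 nM to 200000 nM.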

Compound 4, half-maximal inhibitory concentration: 177000 nM
Beside the measured number, compound 4's estimate is 1.8-fold (0.25 log units) below it; the measured number falls inside the stated range.
By their numbers in this assay, from the lowest: compound 1; then compounds 2, 4 and 3 (each within the scatter of the next).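

Going by these compounds alone, replacing dimethylamino with piperidin-1-yl on this saturated ring carbon gives a 1.1-fold lower number from compound 3 to compound 4 (0.04 log units; within the scatter) in this assay, the first measured change at this group. In this assay, the position therefore accepts the added six-membered non-aromatic ring without a step beyond the scatter, while the count of hydrogen-bond donors and acceptors stays the same. Nothing among the data offers an explanation for this result.

As far as these compounds go, whether a morpholin-4-yl group or a primary amine on the same ring carbon would also stay within the scatter remains open. From the compounds shown here alone, it is also open whether piperidin-1-yl would give a similar step in a compound carrying the (4-methylpiperazin-1-yl)methyl group of compound 2, or the ester and pyrrolidine side chain of compound 1.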